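The compounds below may be only part of what the source reports. "The series", "measured", "known", "first", "only" and "open" are said of these compounds alone.

Measured so far in a functional assay on HepG2 cells (Homo sapiens) for cytotoxicity, read by MTT assay, with a stated time of 72 h; on this read-out lower numbers stand for stronger inhibition and higher numbers for weaker inhibition: compound 1 `COc1ccc(C(=O)NC[C@H]2c3[nH]c4ccccc4c3C[C@H]3[C@H]4c5[nH]c6ccccc6c5C[C@@H]([C@H](C#N)N23)N4C)cc1` gives 310 nM; compound 2 `CN1[C@@H]2c3[nH]c4ccccc4c3C[C@H]1[C@H](C#N)N1[C@@H](CNC(=O)c3ccc4ccccc4n3)c3[nH]c4ccccc4c3C[C@@H]21` gives 110 nM; compound 3 `CN1[C@@H]2c3[nH]c4ccccc4c3C[C@H]1[C@H](C#N)N1[C@@H](CNC(=O)/C=C/c3ccccc3)c3[nH]c4ccccc4c3C[C@@H]21` gives 470 nM.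

Compound 3 carries the highest number of the three; the gap to compound 1 lies within the scatter, while the other gap lies beyond it: a 4.3-fold higher number from compound 2 to compound 3 (0.63 log units; beyond the scatter). The step now considered is from compound 3 to compound 4 `COc1ccc(/C=C/C(=O)NC[C@H]2c3[nH]c4ccccc4c3C[C@H]3[C@H]4c5[nH]c6ccccc6c5C[C@@H]([C@H](C#N)N23)N4C)cc1`: methoxy in place of hydrogen on an aromatic carbon. Within the data shown here, no measured pair shows this change on its own; the nearest is a 1.5-fold higher number from compound 1 to compound 3 (0.18 log units; within the scatter), where the 4-methoxyphenyl amide of compound 1 and the 2-phenylethenyl amide of compound 3 sit within the scatter of one another, and a 2.8-fold lower number from compound 1 to compound 2 (0.45 log units; beyond the scatter), which concerns a different part. On this basis compound 4 is expected to stay within the scatter of compound 3, estimated step a 1.3-fold lower number from compound 3 to compound 4 (0.13 log units; within the scatter). Compound 4 is estimated at 350 nM, range 150 nM to 800 nM.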

Compound 4, half-maximal inhibitory concentration: 2140 nM
Estimate against measurement, compound 4: 6.1-fold (0.79 log units) below; the measured number lies above the stated range.
By their numbers in this assay, from the lowest: compound 2; then compounds 1 and 3 (each within the scatter of the next); then compound 4.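

In this assay, methoxy on the aromatic carbon para to a large group is not neutral on the 2-phenylethenyl amide (a 4.6-fold higher number from compound 3 to compound 4 (0.66 log units; beyond the scatter)). Compound 1 carries the same 4-methoxyphenyl group without the ethenyl link and keeps the lower number (a 6.9-fold higher number from compound 1 to compound 4 (0.84 log units; beyond the scatter)), and the gap to the quinolin-2-yl amide is large (a 19-fold higher number from compound 2 to compound 4 (1.29 log units; beyond the scatter)). No measured evidence here explains this loss.

In the compounds shown, only hydrogen and methoxy occupy this carbon, so it remains open whether the loss is specific to methoxy. A hydroxyl, an amine or a carboxylic acid at that carbon would test this.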